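From Methoxy to Ethoxy

The compounds below may be only part of what the source reports. "The series", "measured", "known", "first", "only" and "open" are said of these compounds alone.

In a functional assay on the whole organism with Rattus norvegicus as the target (on this read-out lower numbers stand for an effect already at smaller amounts and higher numbers for an effect only at larger amounts of compound), compound 1 `COc1ccc2c(O)cc(=O)n(Cc3ccc(-c4ccccc4-c4nn[nH]n4)cc3)c2c1` gives 1.08 mg/kg. Going by the values given here, compound 2 `COc1ccc2c(O)c(-c3ccccc3)c(=O)n(Cc3ccc(-c4ccccc4-c4nn[nH]n4)cc3)c2c1` gives 2.5 mg/kg, the higher of the two numbers so far. Putting phenyl in place of hydrogen on an aromatic carbon produced a 2.3-fold higher number from compound 1 to compound 2 (0.36 log units; beyond the scatter), a modest change. Compound 3 `CCOc1ccc2c(O)c(-c3ccccc3)c(=O)n(Cc3ccc(-c4ccccc4-c4nn[nH]n4)cc3)c2c1` differs from compound 2 at another place: methyl in place of hydrogen on a saturated chain carbon bound to an oxygen on an aromatic ring. This is methyl in place of hydrogen on a saturated chain carbon bound to an oxygen on an aromatic ring, turning methoxy into ethoxy. Among the compounds with values here, the only measured step, a 2.3-fold higher number from compound 1 to compound 2 (0.36 log units; beyond the scatter), involved a different group at a different place, so it offers only a rough sense of scale. Within the data shown here, no measured step tests this change directly. In this assay no shift beyond the scatter is therefore expected, although the uncertainty is wide. The expected result is a 1.1-fold higher number from compound 2 to compound 3 (0.05 log units; within the scatter). The estimate for compound 3 is 2.8 mg/kg, within an expected range of 1.1 mg/kg to 7 mg/kg.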

Compound 3, dose for 50% inhibition: 1.3 mg/kg
Beside the measured number, compound 3's estimate is 2.2-fold (0.33 log units) above it; low and high end bracket the measured number.
By their numbers in this assay, from the lowest: compounds 1, 3 and 2 (each within the scatter of the next, the first and the last beyond it).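

Lengthening methoxy to ethoxy gives the first look at this position on the core, and in this assay it produces a 1.9-fold lower number from compound 2 to compound 3 (0.28 log units; within the scatter). That step stays within the scatter, so compound 2 and compound 3 cannot be told apart, and the added methyl on this saturated chain carbon leaves no measurable mark on the dose needed. Nothing available explains this outcome.

From the compounds shown here alone, a longer chain such as propoxy, a branched group such as isopropoxy, or an amine at the end of the chain could still give a clear shift, so the reach of this result remains open. It is also unknown whether ethoxy would behave the same way on compound 1, which has hydrogen in place of the phenyl.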